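Swapping the aryl group on a naphthoquinone-linked amidine

This account rests on a few compounds, and the source may have more. Where it says the series, first, only, none or still open, it means among the compounds named here.

Measured so far:
compound 1, `COc1ccc(N/C(CCNC2=CC(=O)c3ccccc3C2=O)=N\S(=O)(=O)c2ccc(C)cc2)cc1`, 12000 nM in a functional assay on DU-145 cells (Homo sapiens) for cytotoxicity, read by MTT assay, with a stated time of 48 h; a lower number here means a stronger inhibitor, a higher number a weaker inhibitor
compound 2, `Cc1ccc(S(=O)(=O)/N=C(/CCNC2=CC(=O)c3ccccc3C2=O)Nc2ccc(Cl)cc2)cc1`, 32400 nM

Compound 1 has the lowest number of the two, with compound 2 nearest at a 2.7-fold higher number from compound 1 to compound 2 (0.43 log units; beyond the scatter). Compound 3, `Cc1ccc(S(=O)(=O)/N=C(/CCNC2=CC(=O)c3ccccc3C2=O)Nc2ccc(F)c(F)c2)cc1`, differs from compound 1 by 3,4-difluorophenyl in place of 4-methoxyphenyl on an amine nitrogen. For the measured compounds named here, the only step that bears on this is the one where chloro replaced methoxy on an aromatic carbon, a 2.7-fold higher number from compound 1 to compound 2 (0.43 log units; beyond the scatter), a modest loss. Since compound 3 also trades the methoxy for halogens, a similar weakening is expected, a 2.1-fold higher number from compound 1 to compound 3 (0.32 log units; beyond the scatter). Compound 3 is therefore estimated at 25000 nM, within 10000 nM to 60000 nM.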

Compound 3, half-maximal inhibitory concentration: 12900 nM
Compound 3: middle estimate off by 1.9-fold (0.29 log units), on the high side; measured number inside the range.
By their numbers in this assay, from the lowest: compounds 1 and 3 (each within the scatter of the next); then compound 2.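

Putting halogens on this aryl group does not by itself weaken the compound: in this assay, 3,4-difluorophenyl in place of 4-methoxyphenyl on the amine nitrogen gives a 1.1-fold higher number from compound 1 to compound 3 (0.03 log units; within the scatter), so these two groups cannot be told apart. Set against 4-chlorophenyl, the same group gives a 2.5-fold lower number from compound 2 to compound 3 (0.40 log units; beyond the scatter), which leaves 4-chlorophenyl as the only one of the three groups with a higher number. Nothing measured here explains why the two halogen-bearing groups differ. Still open, from the compounds shown here alone, is how a plain phenyl or a pyridyl group would behave on this nitrogen, and whether replacing the tolyl group on the sulfonyl would matter as much.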